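Notes on the pyridin-2-yl step in the series

A few compounds are considered here, and "the series" means these few. Any claim that something is new, unique, unknown or untested is made for them only; others in the source may bear on it.

Three compounds sharing one core have numbers in a functional assay on A549 cells (Homo sapiens) for antiproliferative activity, read by MTT assay, with a stated time of 72 h; a lower number here means a stronger inhibitor, a higher number a weaker inhibitor: compound 1 `COc1ccc(N2CCN(C(=S)SCc3ccc4nc(N)nc(N)c4c3)CC2)cc1` gives 1590 nM, compound 2 `Cc1ccc(N2CCN(C(=S)SCc3ccc4nc(N)nc(N)c4c3)CC2)c(C)c1` gives 3000 nM, and compound 3 `Nc1nc(N)c2cc(CSC(=S)N3CCN(c4ccccc4[N+](=O)[O-])CC3)ccc2n1` gives 4360 nM. The numbers show a 2.7-fold higher number from compound 1 to compound 3 (0.44 log units; beyond the scatter) and a 1.5-fold higher number from compound 2 to compound 3 (0.16 log units; within the scatter), so compound 3 stands apart from compound 1 only.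

Compound 4 `Nc1nc(N)c2cc(CSC(=S)N3CCN(c4ccccn4)CC3)ccc2n1` is still unmeasured. It carries pyridin-2-yl in place of 2-nitrophenyl on an amine nitrogen in a ring.

The same place changes in all three measured steps. Besides the two above, the series shows a 1.9-fold higher number from compound 1 to compound 2 (0.28 log units; within the scatter). Among the measured compounds shown here, only the step to compound 3 from compound 1 passes the scatter, and only modestly. For the measured compounds named here, no measured compound carries pyridin-2-yl, so the direction of the new step is poorly defined. No step beyond the scatter is therefore expected in this assay.

The expected change is a 1.5-fold lower number from compound 3 to compound 4 (0.16 log units; within the scatter). The estimate for compound 4 is 3000 nM, with an expected range of 1300 nM to 7000 nM.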

Compound 4, half-maximal inhibitory concentration: 3960 nM
Compound 4: the middle estimate sits 1.3-fold (0.12 log units) below what was measured, within the range that was stated.
By their numbers in this assay, from the lowest: compounds 1, 2, 4 and 3 (each within the scatter of the next, the first and the last beyond it).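

Pyridin-2-yl on an amine nitrogen in a ring is accommodated in this assay without a clear shift from the two closest groups: replacing 2-nitrophenyl gives a 1.1-fold lower number from compound 3 to compound 4 (0.04 log units; within the scatter) and replacing 2,4-dimethylphenyl gives a 1.3-fold higher number from compound 2 to compound 4 (0.12 log units; within the scatter) here. Among the compounds shown here, a ring with 1 hetero atom and 6 heavy atoms therefore reads the same at this place as 2-nitrophenyl with its 9 heavy atoms, while the comparison with 4-methoxyphenyl shows a 2.5-fold higher number from compound 1 to compound 4 (0.40 log units; beyond the scatter) as the only new step past the scatter. No measurement here accounts for these numbers.

As far as these compounds go, what a benzyl group or an acetyl group would give on this nitrogen remains open. Also open, from the compounds shown here alone, is whether pyridin-4-yl would read like pyridin-2-yl, or whether a methoxy group added to the pyridine ring would bring the number towards that of compound 1.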